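Furan for Methoxyphenyl on a Double-Bonded Chain Carbon

The source may report more compounds than this note shows. Statements on the series, on what has been measured and on what is new or still open speak of the compounds shown alone.

Compound 1 `COc1ccc(/C=C/C(=O)c2ccc(NC(=O)C(C)Br)cc2)cc1` gives 40% in a functional assay on the whole organism (strain albino) for inhibition, with Rattus norvegicus as the target, read by paw edema, with stated times of 30 min and 2 h, at a dose of 100 mg/kg by the oral route; on this read-out lower numbers stand for less inhibition and higher numbers for more inhibition at the one dose given (going by the name of the read-out). Compound 2 `CC(Br)C(=O)Nc1ccc(C(=O)/C=C/c2ccco2)cc1` carries furan-2-yl in place of 4-methoxyphenyl on a double-bonded chain carbon bound to a double-bonded chain carbon and gives 37% in this assay, so that a number 3 percentage points lower from compound 1 to compound 2 (within the scatter). Compound 3 `COc1ccc(/C=C/C(=O)c2ccc(NC(=O)COc3ccc(/C(C)=N\O)cc3)cc2)cc1` shares only part of its structure with compound 1; the difference between the two cores is not broken down here. In this assay compound 3 gives 41%, the highest of the three numbers, though every gap to the others stays within the scatter. Compound 4 `C/C(=N/O)c1ccc(OCC(=O)Nc2ccc(C(=O)/C=C/c3ccco3)cc2)cc1` is the unmeasured partner of compound 3 and carries furan-2-yl in place of 4-methoxyphenyl on a double-bonded chain carbon bound to a double-bonded chain carbon, the same change seen once before. The expected step is a number 3 percentage points lower from compound 3 to compound 4 (within the scatter), because a number 3 percentage points lower from compound 1 to compound 2 (within the scatter) stayed within the scatter. Compound 4 is therefore expected to give 38% in this assay, with an estimated range from 28% to 48%.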

Compound 4, a percentage reported as inhibition, in the whole organism at one dose (the size of the read-out at that dose, not a potency): 44%
For compound 4 the middle estimate is 6 percentage points below the measured one; the range from low to high includes it.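

In this assay, putting furan-2-yl in place of 4-methoxyphenyl gives a number 3 percentage points higher from compound 3 to compound 4 (within the scatter). Set side by side, the steps on the two cores do not differ beyond what repeated measurement allows: the same change on two cores in this assay, a number 3 percentage points lower (within the scatter) from compound 1 to compound 2 and a number 3 percentage points higher (within the scatter) from compound 3 to compound 4, 6 percentage points apart, within the scatter of two such steps. The change therefore carries between these two cores without a step beyond the scatter, but two pairs, each within the scatter, do not show that it has any effect of its own or that it would behave alike on a third core.

The compounds shown leave open whether a different group at this place, such as an amine or a carboxylic acid, would shift the read-out beyond the scatter. They also leave open how either ring would read at other doses.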